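A few compounds are considered here, and "the series" means these few. Any claim that something is new, unique, unknown or untested is made for them only; others in the source may bear on it.

Values measured so far in an ADME assay on microsomes from liver (Mus musculus) for metabolic stability, read by LC-MS, with a stated time of 30 min, tested at 1 uM (on this read-out higher numbers stand for a more stable compound and lower numbers for a less stable compound), are these:
- compound 1 (`O=C(NCc1ccc(S(=O)(=O)c2cccc(F)c2)cc1)c1cc2cnccc2[nH]1`): (44%)
- compound 2 (`O=C(NCc1ccc(S(=O)(=O)N2CCCCC2)cc1)c1cc2cnccc2s1`): ("below limit of detection" (no number reported))
- compound 3 (`O=C(NCc1ccc(S(=O)(=O)c2ccccc2)cc1)c1ccc2cnccc2c1`): (10%)

Compound 1 holds the highest of the two numbers (44%). The nearest is compound 3 (10%), and that gap lies beyond the usual scatter. These two compounds differ in more than one place, so their values show only where each stands.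

The next compound to be read is compound 4 (`O=C(NCc1ccc(S(=O)(=O)c2cccc(C(F)(F)F)c2)cc1)c1cc2cnccc2[nH]1`). It keeps the core of compound 1 and carries trifluoromethyl in place of fluoro on an aromatic carbon, meta to a large group (trifluoromethyl in place of fluoro on an aromatic carbon). Among the compounds with values here, the series holds no measured pair that differs in one place only, so no measured step gives a size for this change. The starting point for the expectation is compound 1 (44%), and the range has to stay wide.

In this assay the estimated step of a number 6 percentage points lower from compound 1 to compound 4 (within the scatter) is a small fall, expected to stay within the scatter. For compound 4 the estimate is 38% as the expected value, with an expected range from 18% to 60% as its upper end.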

Compound 4, percent of the compound remaining: 49%
Beside the measured number, compound 4's estimate is 11 percentage points below it, within the range that was stated.
By their numbers in this assay, from the lowest: compound 3; then compounds 1 and 4 (each within the scatter of the next).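

In this assay, the series now has its first pair that differs in one place only, and the exchange of 3-fluorophenyl for 3-(trifluoromethyl)phenyl gives a number 5 percentage points higher from compound 1 to compound 4 (within the scatter) in this read-out. At this aromatic carbon, meta to a large group, the substituent goes from 1 heavy atom to 4 heavy atoms, and the read-out does not separate the two compounds, a result that holds only for this pair on the core of compound 1. No accompanying measurement bears on what lies behind this result.

At this carbon only fluoro and trifluoromethyl are shown, so the reading for a nitrile, a methoxy group, an amine or a carboxylic acid there remains open, as does the reading for the unsubstituted phenyl on the core of compound 1. As far as these compounds go, compound 2 and compound 3 each differ from compound 1 in more than one place, so the separate contributions of the core and of the group on the sulfonyl remain open too.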